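The compounds below may be only part of what the source reports. "The series", "measured", "known", "first", "only" and "open" are said of these compounds alone.

In a physicochemical assay for solubility, using the shake flask method, in simulated intestinal fluid, measured as kinetic solubility, with a stated time of 2 h, at 25 degrees C, at pH 6.5 (a higher number here means a more soluble compound, a lower number a less soluble compound), compound 1 `Cc1nc(C(=O)N(C)C)c(N)c2c1C(=O)N(Cc1ccccc1)C2=O` gives 172000 nM as a measured number. Compound 2 `Cc1noc(-c2nc(C)c3c(c2N)C(=O)N(Cc2cccc(F)c2)C3=O)n1` gives < 5000 nM as a limit of the assay and not a number. Compound 3 `Cc1noc(-c2nc(C)c3c(c2N)C(=O)N(Cc2cccc(C(F)(F)F)c2)C3=O)n1` gives < 5000 nM as a limit too and not a number. Compound 3 thus shares the limit of < 5000 nM in this assay, at which 2 of the 3 values shown sit, and has no readable place of its own on the scale.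

Compound 4 `Cc1noc(-c2nc(C)c3c(c2N)C(=O)N(Cc2ccc(Cl)cn2)C3=O)n1` differs from compound 3 as follows: 5-chloropyridin-2-yl in place of 3-(trifluoromethyl)phenyl on a saturated chain carbon bound to an amide-type nitrogen in a ring and so 5-chloropyridin-2-yl takes the place of 3-(trifluoromethyl)phenyl on a saturated chain carbon bound to an amide-type nitrogen in a ring. The nearest measured step is a step that the two limits leave unreadable from compound 2 to compound 3 and gives no size to carry over. No firm direction can therefore be expected in this assay and only a small change is assumed. The estimated step that the limit leaves unreadable from compound 3 to compound 4 is expected to stay small and may well end at the same limit. Compound 4 is estimated at 4000 nM with an expected range from 1200 nM to 15000 nM on this reading.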

Compound 4, solubility: < 5000 nM
Compound 4 was reported as a limit; the forecaster's own chance of this, stated with the estimate: 65%; the middle value is on the limit's open side.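

In this assay compound 4 gives < 5000 nM, a limit of the assay and not a number, so no step from compound 2 or compound 3 to compound 4 can be read: the limit of < 5000 nM in this assay, at which 3 of the 4 values shown sit.

The compounds shown leave open where compound 2, compound 3 and compound 4 actually stand on the scale, and whether their different aromatic groups separate them at all.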